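The source may hold more compounds than are shown below. What is called first, only, known or untested is meant among the compounds shown, and "the series" means these compounds.

Working notes on the series.

The three measured compounds share one core and differ only in the group on the amine nitrogen in the ring. Compound 1 `NC(=O)c1c(NC(=O)c2ccccc2Cl)sc2c1CCN(Cc1ccccc1)C2` gives 12000 nM in a functional assay on HL-60 cells (Homo sapiens) for antiproliferative activity, with a stated time of 24 h; a higher number here means a weaker inhibitor, a lower number a stronger inhibitor. Compound 2 `NC(=O)c1c(NC(=O)c2ccccc2Cl)sc2c1CCN(C(=S)Nc1ccccc1)C2` gives 5940 nM, and compound 3 `NC(=O)c1c(NC(=O)c2ccccc2Cl)sc2c1CCN(C(=O)Nc1ccccc1Cl)C2` gives 12500 nM, the highest of the three numbers; the step of a 1.0-fold higher number from compound 1 to compound 3 (0.02 log units; within the scatter) lies within the scatter, while a 2.1-fold higher number from compound 2 to compound 3 (0.32 log units; beyond the scatter) does not. The step of a 2.0-fold lower number from compound 1 to compound 2 (0.31 log units; beyond the scatter) goes the other way.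

Compound 4 `Cc1ccccc1NC(=S)N1CCc2c(sc(NC(=O)c3ccccc3Cl)c2C(N)=O)C1` is not yet measured. The change is a group of 10 heavy atoms (8 carbon, 1 nitrogen, 1 sulfur; one six-membered aromatic ring of carbon only) in place of a group of 10 heavy atoms (7 carbon, 1 nitrogen, 1 oxygen, 1 chlorine; one six-membered aromatic ring of carbon only), on an amine nitrogen in a ring. It bears most directly on the step from compound 3 back toward the thiourea of compound 2, since compound 4 also carries a thiourea, now with an added methyl on the aromatic ring. The most relevant measured step is a 2.1-fold higher number from compound 2 to compound 3 (0.32 log units; beyond the scatter), modest and beyond the scatter; reversed, it points to a lower number for compound 4. Going by the values given here, the methyl has no measured counterpart here, so its effect cannot be read from the data. For compound 4 the expected step is a 1.9-fold lower number from compound 3 to compound 4 (0.28 log units; within the scatter), and the estimate for compound 4 is 6500 nM, with a range from 3000 nM to 14000 nM.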

Compound 4, half-maximal inhibitory concentration: 22600 nM
Compound 4: middle estimate off by 3.5-fold (0.54 log units), on the low side, and the stated range ends below it.
By their numbers in this assay, from the lowest: compound 2; then compounds 1, 3 and 4 (each within the scatter of the next).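

Methyl in place of hydrogen on an aromatic carbon gives a 3.8-fold higher number from compound 2 to compound 4 (0.58 log units; beyond the scatter), so the thiourea alone does not carry the lower number of compound 2 over to compound 4. Both a 1.8-fold higher number from compound 3 to compound 4 (0.26 log units; within the scatter) and a 1.9-fold higher number from compound 1 to compound 4 (0.27 log units; within the scatter) stay within the scatter, which leaves compound 2 as the only one of the four set apart from all the others. No available evidence accounts for the methyl step.

The compounds shown leave open whether a thiourea with chlorine, methoxy or an amine on the aromatic ring would stay near compound 2 or near compound 4. They also leave open how a urea with a plain phenyl, lacking the chlorine of compound 3, would compare with the thiourea of compound 2.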